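Swapping a phenoxy for a benzoyl on a shared amide core

The compounds below may be only part of what the source reports. "The series", "measured", "known", "first", "only" and "open" are said of these compounds alone.

Of the compounds shown here, three sharing one core have been tested in an ADME assay on PC-3 cells (Homo sapiens) for cytotoxicity, read by WST assay, tested at 100 uM; a lower number here means less inhibition, a higher number more inhibition at the concentration tested (going by the name of the read-out). Compound 1 `O=C(Nc1cccc(-c2cnco2)c1)C1CCCN(C(=O)c2cc(C(F)(F)F)cc(C(F)(F)F)c2)C1` gives 9%, compound 2 `O=C(Nc1cccc(CN2CCCC2)c1)C1CCCN(C(=O)c2cc(C(F)(F)F)cc(C(F)(F)F)c2)C1` gives 51%, and compound 3 `O=C(Nc1cccc(Oc2ccccc2)c1)C1CCCN(C(=O)c2cc(C(F)(F)F)cc(C(F)(F)F)c2)C1` gives 1%. Compound 3 thus has the lowest number of the three, but its gap to compound 1, a number 8 percentage points lower from compound 1 to compound 3 (within the scatter), is within the scatter, so the two cannot be told apart; only compound 2 stands clearly apart, as a number 50 percentage points lower from compound 2 to compound 3 (beyond the scatter) shows.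

Compound 4 `O=C(c1ccccc1)c1cccc(NC(=O)C2CCCN(C(=O)c3cc(C(F)(F)F)cc(C(F)(F)F)c3)C2)c1` differs from compound 3 by benzoyl in place of phenoxy on an aromatic carbon. Going by the values given here, no measured step replaces a phenoxy with a benzoyl, so none bears on this change directly. The steps seen so far show a large shift only when a (pyrrolidin-1-yl)methyl is involved, as in a number 42 percentage points higher from compound 1 to compound 2 (beyond the scatter), while the exchange between 1,3-oxazol-5-yl and phenoxy stayed within the scatter. Since both phenoxy and benzoyl carry one carbon-only aromatic ring and one hydrogen-bond acceptor, compound 4 is expected to stay close to compound 3, with a number 5 percentage points higher from compound 3 to compound 4 (within the scatter) expected to lie within the scatter. The estimate for compound 4 in this assay is 6%, within a range of -8% to 22%.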

Compound 4, a percentage reported as inhibition, at one concentration (the size of the read-out at that concentration, not a potency): 0%
Beside the measured number, compound 4's estimate is 6 percentage points above it; low and high end bracket the measured number.
By their numbers in this assay, from the lowest: compounds 4, 3 and 1 (each within the scatter of the next); then compound 2.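

In this assay, benzoyl and phenoxy cannot be told apart at this position, meta to a large group (a number 1 percentage points lower from compound 3 to compound 4 (within the scatter)). Benzoyl also cannot be told apart from 1,3-oxazol-5-yl (a number 9 percentage points lower from compound 1 to compound 4 (within the scatter)), so among these four compounds only the (pyrrolidin-1-yl)methyl group stands apart (a number 51 percentage points lower from compound 2 to compound 4 (beyond the scatter)), and no compound goes against this. Nothing available here explains why that one group differs.

Still open, going by these compounds, is whether the higher number belongs to the pyrrolidine ring in particular or would also appear with another amine, such as a piperidine or a dimethylamino group, or with a longer chain carrying the same ring. A carboxylic acid at this position would also show whether a very different group can shift the number from the low values of the other three compounds.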